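The source may hold more compounds than are shown below. What is called first, only, known or untested is meant among the compounds shown, and "the series" means these compounds.

Working notes on the series. Three compounds share one core and differ only in the group carried on a saturated ring carbon. Compound 1 `COc1cc(N2C(N)=C(C#N)C(c3c(OC)ccc4ccccc34)C3=C2CC(C)(C)CC3=O)cc(OC)c1OC` gives 0% in a functional assay on Ehrlich cells (Mus musculus) for cytotoxicity, tested at 10 ug/mL; a lower number here means a weaker effect, a higher number a stronger effect of the compound at the concentration tested. Compound 2 `COc1cc(N2C(N)=C(C#N)C(c3ccc(OC)c4ccccc34)C3=C2CC(C)(C)CC3=O)cc(OC)c1OC` gives 10% in this assay, and compound 3 `COc1cc(N2C(N)=C(C#N)C(c3cccc([N+](=O)[O-])c3)C3=C2CC(C)(C)CC3=O)cc(OC)c1OC` gives 5% in this assay. All three numbers lie close together: the step of a number 10 percentage points higher from compound 1 to compound 2 (within the scatter) is within the scatter, as are a number 5 percentage points higher from compound 1 to compound 3 (within the scatter) and a number 5 percentage points lower from compound 2 to compound 3 (within the scatter). Compound 3 therefore sits between the other two numbers without being separated from either beyond the scatter.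

Compound 4 `COc1cc(N2C(N)=C(C#N)C(c3ccc(C)o3)C3=C2CC(C)(C)CC3=O)cc(OC)c1OC` has not yet been measured. It differs from compound 3 in the same place where the three measured compounds differ from one another: 5-methylfuran-2-yl in place of 3-nitrophenyl on a saturated ring carbon. The three measured steps at this position bear on it, and none of them moved the read-out beyond the scatter, whether a methoxynaphthyl group was exchanged for another or for 3-nitrophenyl. Nothing in the shown numbers points to a step in either direction for a 5-methylfuran-2-yl group here. The step from compound 3 to compound 4 is therefore expected to be no change at the digits printed from compound 3 to compound 4 (within the scatter), within the scatter. For compound 4 the estimated value in this assay is 5%, with a range from 0% to 20%.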

Compound 4, a percentage reported as activity, at one concentration (the size of the read-out at that concentration, not a potency): 21%
Compound 4: middle estimate off by 16 percentage points, on the low side; measured number outside the range, above it.
By their numbers in this assay, from the lowest: compounds 1, 3 and 2 (each within the scatter of the next); then compound 4.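

In this assay, among the compounds shown here, this position no longer looks silent: the change to 5-methylfuran-2-yl gives a number 16 percentage points higher from compound 3 to compound 4 (beyond the scatter), a number 11 percentage points higher from compound 2 to compound 4 (beyond the scatter) and a number 21 percentage points higher from compound 1 to compound 4 (beyond the scatter), whereas no step among the earlier compounds lay beyond the scatter. Compound 4, the only one here with a five-membered aromatic ring with 1 hetero atom on the saturated ring carbon, stands apart from all three others, so the group at this place can move the read-out, though each of these steps is only modest. No supporting data are available to explain this result.

The compounds shown leave open whether the step belongs to the furan ring itself or to its methyl group, a question that furan-2-yl without the methyl group, 5-ethylfuran-2-yl or thiophen-2-yl at the same carbon would address. It also remains open whether a basic amine or a carboxylic acid on the furan ring would take the read-out further, and a single tested concentration gives no potency for any of these compounds.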